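The source may report more compounds than this note shows. Statements on the series, on what has been measured and on what is new or still open speak of the compounds shown alone.

Working notes on the series. For the measured compounds named here, in a functional assay on A549 cells (Homo sapiens) for cytotoxicity, read by MTT assay, with a stated time of 48 h (a higher number here means a weaker inhibitor, a lower number a stronger inhibitor), compound 1 (`COc1ccc(/C=C/c2cc(OC)c(OC)c(OC)c2-c2ccccc2)cc1`) gives 36000 nM and compound 2 (`COc1ccc(/C=C/c2cc(OC)c(OC)c(OC)c2-c2ccc(Cl)cc2)cc1`) gives 30000 nM as the only two values so far. Compound 1 therefore stands level with compound 2, and no order can be drawn between them. Going by the values given here, the one measured step, a 1.2-fold lower number from compound 1 to compound 2 (0.08 log units; within the scatter), puts chloro in place of hydrogen on an aromatic carbon and lies within the scatter.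

Compound 3 (`COc1cc(/C=C/c2ccccc2)c(-c2ccccc2)c(OC)c1OC`) departs from compound 1 by hydrogen in place of methoxy on an aromatic carbon, or 4-methoxyphenyl to phenyl. Among the compounds with values here, no measured pair makes this change, so the step to compound 2 bears on it only indirectly, as the sole sign of how the values respond to a single change on this core. That evidence is thin and gives no direction. No shift beyond the scatter is therefore expected in this assay, and the expected 1.1-fold lower number from compound 1 to compound 3 (0.05 log units; within the scatter) is an estimate only. For compound 3 the estimated value is 32000 nM with an expected range from 13000 nM to 80000 nM in this assay.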

Compound 3, half-maximal inhibitory concentration: 79000 nM
Compound 3: middle estimate off by 2.5-fold (0.39 log units), on the low side; the range from low to high includes it.
By their numbers in this assay, from the lowest: compounds 2 and 1 (each within the scatter of the next); then compound 3.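

In this assay, for the compounds shown here, the methoxy on an aromatic carbon, para to a large group, is the first place on the core of compound 1 where a single change moves the number beyond the scatter (a 2.2-fold higher number from compound 1 to compound 3 (0.34 log units; beyond the scatter)). Going from 4-methoxyphenyl to phenyl therefore gives a weaker inhibitor, although the shift is modest and rests on this one pair, whereas the chloro step (a 1.2-fold lower number from compound 1 to compound 2 (0.08 log units; within the scatter)) left its two compounds unseparated, so the earlier values gave no sign that any place on this core could respond. No measurement at hand bears on why removing the methoxy raises the number.

The compounds shown leave open whether the rise belongs to methoxy in particular or would follow any replacement at this place, which an ethoxy, a hydroxy, a fluoro or an amine there would begin to separate. Also open, on these data alone, is whether the same change would give a similar shift on the chloro-bearing compound 2, and whether any group at this place gives a lower number than compound 1.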